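Ortho-chloro on the phenylpiperazine of a thiosemicarbazone series

The source may hold more compounds than are shown below. What is called first, only, known or untested is meant among the compounds shown, and "the series" means these compounds.

The measured compounds:
Compound 1, `O=C1Nc2ccc(Br)cc2/C1=N/NC(=S)N1CCN(c2ccccc2)CC1`, gives 20500 nM in a functional assay on MCF7 cells (Homo sapiens) for inhibition, read by MTT assay, with a stated time of 72 h; a lower number here means a stronger inhibitor, a higher number a weaker inhibitor.
Compound 2, `O=C1Nc2ccc(Cl)cc2/C1=N/NC(=S)N1CCN(c2ccccc2)CC1`, gives 10400 nM in this assay.
Compound 3, `O=C1Nc2ccc([N+](=O)[O-])cc2/C1=N/NC(=S)N1CCN(c2ccccc2)CC1`, gives 23300 nM in this assay.

Compound 2 stands at the low end of these three numbers. Against compound 1 the step of a 2.0-fold lower number from compound 1 to compound 2 (0.29 log units; within the scatter) is within the scatter, so the two cannot be ranked; against compound 3 the step of a 2.2-fold higher number from compound 2 to compound 3 (0.35 log units; beyond the scatter) is modest but beyond it. The third measured step, a 1.1-fold higher number from compound 1 to compound 3 (0.06 log units; within the scatter), is again within the scatter. All three steps concern the group on the aromatic ring of the shared core.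

Compound 4, `O=C1Nc2ccc(Cl)cc2/C1=N/NC(=S)N1CCN(c2ccccc2Cl)CC1`, differs from compound 2 elsewhere: chloro in place of hydrogen on an aromatic carbon. Going by the values given here, no measured step touches the phenyl on the piperazine, so nothing in the data bears directly on this change. The expectation therefore rests on compound 2 alone, and the step is expected to stay within the usual scatter in this assay, with no direction favoured. For compound 4 the estimated value is 9500 nM, within a range of 3500 nM to 26000 nM. From compound 2 this expected step reads a 1.1-fold lower number from compound 2 to compound 4 (0.04 log units; within the scatter).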

Compound 4, half-maximal inhibitory concentration: 11700 nM
Beside the measured number, compound 4's estimate is 1.2-fold (0.09 log units) below it; measured number inside the range.
By their numbers in this assay, from the lowest: compounds 2, 4, 1 and 3 (each within the scatter of the next, the first and the last beyond it).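

Going by these compounds alone, on the phenyl of the piperazine, which no earlier step touched, chloro in place of hydrogen, ortho to a large group, gives a 1.1-fold higher number from compound 2 to compound 4 (0.05 log units; within the scatter) in this assay and leaves compound 2 and compound 4 unranked. Within the data shown here, the earlier compounds varied only the group on the aromatic ring of the shared core, and this pair is the first reading at a second site: going from phenyl to 2-chlorophenyl brings no change that can be told from the scatter. Nothing measured here offers an explanation for this result.

On these data alone, whether other groups at this place would behave the same stays open, for instance methoxy, an amine, a carboxylic acid or a longer chain, as does the outcome of chloro elsewhere on that phenyl. Among these compounds, the change is also seen only on the chloro-bearing core of compound 2, so it remains unknown whether the same replacement would read alike with bromo or nitro on the core.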